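Phenyl to piperidin-4-yl on a fused bicyclic core

The compounds below may be only part of what the source reports. "The series", "measured", "known", "first", "only" and "open" are said of these compounds alone.

Measured compounds:
- Compound 1, `Cn1cc(-c2cnc3[nH]cc(-c4ccnc(C#N)c4)c3c2)cn1`: 2000 nM
- Compound 2, `Cn1cc(-c2cnc3[nH]cc(-c4ccccc4)c3c2)cn1`: 20000 nM

Of the compounds shown here, two sharing the same core have been measured in a physicochemical assay for solubility, read by LC-MS, in phosphate buffer, measured as thermodynamic solubility, with a stated time of 24 h, at pH 7.4; on this read-out higher numbers stand for higher solubility and lower numbers for lower solubility. Compound 2 holds the higher of the two numbers; compound 1 sits a full step below it, and that gap lies beyond the usual scatter, so the two values genuinely differ. Among the measured compounds shown here, no step between measured compounds that differ in a single place is available, so the two numbers stand on their own.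

Compound 3, `Cn1cc(-c2cnc3[nH]cc(C4CCNCC4)c3c2)cn1`, has not yet been measured. It differs from compound 2 in one place:

piperidin-4-yl in place of phenyl on an aromatic carbon

The entering piperidin-4-yl carries one hydrogen-bond donor and one hydrogen-bond acceptor where phenyl carried none. For compound 3 an upward step in this assay is expected, larger than the scatter, of about a 10-fold higher number from compound 2 to compound 3 (1.00 log units; beyond the scatter). Compound 3 is therefore estimated at 200000 nM, within a range from 50000 nM to 800000 nM.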

Compound 3, solubility: 770000 nM
Compound 3: the middle estimate sits 3.9-fold (0.59 log units) below what was measured, and the stated range covers the measured number.
By their numbers in this assay, from the lowest: compound 1; then compound 2; then compound 3.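

Among the compounds shown here, replacing phenyl with piperidin-4-yl on this aromatic carbon gives a 39-fold higher number from compound 2 to compound 3 (1.59 log units; beyond the scatter) in this assay, the first single-place change at this position that can be read. Both groups have 6 heavy atoms, so this large step comes without any change in that count. The change instead swaps an aromatic carbon ring for a non-aromatic ring with a nitrogen, and adds a hydrogen-bond donor and acceptor, and no available data show which of these differences accounts for the step.

From the compounds shown here alone, it remains open whether the ring nitrogen itself matters, a question that cyclohexyl, with no nitrogen, or tetrahydropyran-4-yl, with oxygen in the ring instead, could test on the same carbon. It is also unknown whether the same swap would give a similar step on the core of compound 1, which carries a different aromatic ring at this position.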